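Aryl variation on the shared core: compound 4

A few compounds are considered here, and "the series" means these few. Any claim that something is new, unique, unknown or untested is made for them only; others in the source may bear on it.

Three compounds share one core and differ only in the aryl group on an aromatic carbon of a five-membered aromatic ring with 2 nitrogen. Compound 1 `Cc1nn(-c2nc(-c3ccc(Cl)c(Cl)c3)c(SC(C)C)s2)c(C(=O)O)c1-c1cccc(Cl)c1C` gives 5100 nM in a functional assay on BJAB cells (Homo sapiens) for antiproliferative activity, with a stated time of 4 days; on this read-out lower numbers stand for an effect already at smaller amounts and higher numbers for an effect only at larger amounts of compound. Compound 2 `Cc1nn(-c2nc(-c3ccc(Cl)c(Cl)c3)c(SC(C)C)s2)c(C(=O)O)c1-c1cc(C#N)cc(C(F)(F)F)c1` gives 3600 nM, and compound 3 `Cc1ccc(-c2c(C)nn(-c3nc(-c4ccc(Cl)c(Cl)c4)c(SC(C)C)s3)c2C(=O)O)cc1` gives 3800 nM. Compound 3 holds the second highest of the three numbers; its nearest neighbour is compound 2, with a 1.1-fold higher number from compound 2 to compound 3 (0.02 log units; within the scatter), and its furthest is compound 1, with a 1.3-fold lower number from compound 1 to compound 3 (0.13 log units; within the scatter). The third step, a 1.4-fold lower number from compound 1 to compound 2 (0.15 log units; within the scatter), is also within the scatter, so across these three aryl groups this assay shows no separation at all.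

Compound 4 `Cc1cc(Cl)cc(-c2c(C)nn(-c3nc(-c4ccc(Cl)c(Cl)c4)c(SC(C)C)s3)c2C(=O)O)c1` differs from compound 3 in one place: 3-chloro-5-methylphenyl in place of 4-methylphenyl on an aromatic carbon. All three measured steps bear on this change, since each swaps the same aryl group on the same carbon, and none of them moved the number beyond the scatter. The same is therefore expected here: the step from compound 3 to compound 4 is estimated as no change at the digits printed from compound 3 to compound 4 (within the scatter), nothing beyond the scatter in either direction. For compound 4 the number in this assay is expected to be 3800 nM, with a range from 1900 nM to 7600 nM.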

Compound 4, half-maximal effective concentration: 663 nM
Estimate against measurement, compound 4: 5.7-fold (0.76 log units) above; measured number outside the range, below it.
By their numbers in this assay, from the lowest: compound 4; then compounds 2, 3 and 1 (each within the scatter of the next).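

The aryl group at this position, on an aromatic carbon of a five-membered aromatic ring with 2 nitrogen, can shift the number in this assay beyond the scatter after all: the result is a 5.7-fold lower number from compound 3 to compound 4 (0.76 log units; beyond the scatter), a 5.4-fold lower number from compound 2 to compound 4 (0.73 log units; beyond the scatter) and a 7.7-fold lower number from compound 1 to compound 4 (0.89 log units; beyond the scatter), whereas the three earlier aryl groups could not be told apart. Carrying a chlorine and a methyl on the ring is not enough among these four compounds, since compound 1 carries both as 3-chloro-2-methylphenyl and remains within the scatter of compound 2 and compound 3, so the separation goes with the 3-chloro-5-methylphenyl arrangement in compound 4. No independent measurement is available to explain this separation.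

The compounds shown leave open whether the chlorine, the methyl or only the two together accounts for the step, which 3-chlorophenyl, 3-methylphenyl, 3,5-dichlorophenyl or 3,5-dimethylphenyl at the same carbon would help to separate. On these data alone, it also remains open whether the step from compound 3 to compound 4 carries over when a primary amide stands in place of the carboxy group.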